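Amide to Urea: What to Expect for Compound 4

The compounds below may be only part of what the source reports. "The series", "measured", "known", "first", "only" and "open" are said of these compounds alone.

Of the compounds shown here, three built on one shared core have been tested in a functional assay on SF-268 cells (Homo sapiens) for inhibition, read by sulforhodamine B assay, with a stated time of 48 h; on this read-out lower numbers stand for stronger inhibition of growth and higher numbers for weaker inhibition of growth. Compound 1 `COc1cc(-c2nn(-c3cccc(NC(=O)c4cccc(C(F)(F)F)c4)c3)cc2-c2ccncc2)ccc1Cl` gives 2130 nM. Compound 2 `COc1cc(-c2nn(-c3cccc(NC(=O)Nc4cccc(C(F)(F)F)c4)c3)cc2-c2ccncc2)ccc1Cl` gives 1360 nM. Compound 3 `COc1cc(-c2nn(-c3cccc(NC(=O)c4ccc(Cl)c(C(F)(F)F)c4)c3)cc2-c2ccncc2)ccc1Cl` gives 4860 nM, the highest of the three numbers; the steps of a 2.3-fold higher number from compound 1 to compound 3 (0.36 log units; beyond the scatter) and a 3.6-fold higher number from compound 2 to compound 3 (0.55 log units; beyond the scatter) both lie beyond the scatter. Compound 4 `COc1cc(-c2nn(-c3cccc(NC(=O)Nc4ccc(Cl)c(C(F)(F)F)c4)c3)cc2-c2ccncc2)ccc1Cl` differs from compound 3 by (4-chloro-3-(trifluoromethyl)phenyl)amino in place of 4-chloro-3-(trifluoromethyl)phenyl on a carbonyl carbon. The same kind of change, made on the pair without the chloro, gave a 1.6-fold lower number from compound 1 to compound 2 (0.19 log units; within the scatter), a step within the scatter. The step from compound 3 to compound 4 is therefore expected to be small, toward a lower number or none beyond the scatter, estimated as a 1.6-fold lower number from compound 3 to compound 4 (0.20 log units; within the scatter). Compound 4 is expected to give about 3100 nM in this assay, within a range from 1300 nM to 7500 nM.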

Compound 4, concentration for 50% growth inhibition: 1460 nM
Compound 4: the middle estimate sits 2.1-fold (0.33 log units) above what was measured; measured number inside the range.
By their numbers in this assay, from the lowest: compounds 2, 4 and 1 (each within the scatter of the next); then compound 3.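

Putting the amino form of the group on the carbonyl carbon now gives a 3.3-fold lower number from compound 3 to compound 4 (0.52 log units; beyond the scatter), so with the chloro present this change moves the number beyond the scatter, which the pair without the chloro did not show. On the urea, the chloro gives only a 1.1-fold higher number from compound 2 to compound 4 (0.03 log units; within the scatter), and a 1.5-fold lower number from compound 1 to compound 4 (0.16 log units; within the scatter) is just as small. Still, the data do not show that the chloro acts differently on the amide and on the urea: the same change on two cores in this assay, a 2.3-fold higher number (0.36 log units; beyond the scatter) from compound 1 to compound 3 and a 1.1-fold higher number (0.03 log units; within the scatter) from compound 2 to compound 4, 2.1-fold (0.33 log units) apart, within the scatter of two such steps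

From the compounds shown here alone, what a methyl group or an amine in place of the chloro would do on either linker remains open.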